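Swapping the amide's aryl group for a quinolinyl ring

A few compounds are considered here, and "the series" means these few. Any claim that something is new, unique, unknown or untested is made for them only; others in the source may bear on it.

Compound 2 `CN1[C@@H]2c3[nH]c4ccccc4c3C[C@H]1[C@H](C#N)N1[C@@H](CNC(=O)c3cccc4c3CCCC4)c3[nH]c4ccccc4c3C[C@@H]21` gives 3540 nM in a functional assay on BGC-823 cells (Homo sapiens) for cytotoxicity, read by MTT assay, with a stated time of 72 h (on this read-out lower numbers stand for stronger inhibition and higher numbers for weaker inhibition), the higher of the two numbers measured; compound 1 `CN1[C@@H]2c3[nH]c4ccccc4c3C[C@H]1[C@H](C#N)N1[C@@H](CNC(=O)c3ccc(F)cc3)c3[nH]c4ccccc4c3C[C@@H]21` gives 310 nM. For the measured compounds named here, the single step so far, an 11-fold higher number from compound 1 to compound 2 (1.06 log units; beyond the scatter), came from a bicyclic group replacing a small fluorinated ring. Compound 3 `CN1[C@@H]2c3[nH]c4ccccc4c3C[C@H]1[C@H](C#N)N1[C@@H](CNC(=O)c3ccc4ccccc4n3)c3[nH]c4ccccc4c3C[C@@H]21` carries quinolin-2-yl in place of 1,2,3,4-tetrahydronaphthalen-5-yl on a carbonyl carbon. It keeps a bicyclic group but makes it fully aromatic with a nitrogen, so the prior step gives only loose guidance; a modest move toward compound 1 is expected, a 2.4-fold lower number from compound 2 to compound 3 (0.37 log units; beyond the scatter). Compound 3 is estimated at 1500 nM, between 400 nM and 6000 nM.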

Compound 3, half-maximal inhibitory concentration: 80 nM
Compound 3: the middle estimate sits 19-fold (1.27 log units) above what was measured, and the stated range ends above it.
By their numbers in this assay, from the lowest: compound 3; then compound 1; then compound 2.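

At this place, on a carbonyl carbon, a two-ring group carries no penalty in itself: quinolin-2-yl in place of 1,2,3,4-tetrahydronaphthalen-5-yl gives a 44-fold lower number from compound 2 to compound 3 (1.65 log units; beyond the scatter) and restores activity. Against the single ring of 4-fluorophenyl, the same group gives a 3.9-fold lower number from compound 1 to compound 3 (0.59 log units; beyond the scatter) and puts compound 3 lowest of the three. Nothing measured here explains these differences. Still open, going by these compounds, is whether the ring nitrogen or the fully aromatic second ring matters more, and a naphthalen-2-yl group, aromatic and all carbon, would separate the two.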